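A few compounds are considered here, and "the series" means these few. Any claim that something is new, unique, unknown or untested is made for them only; others in the source may bear on it.

The measured compounds are:

compound 1, `Cc1ccc(NC2=CC(=O)c3c(nc4n3[C@H]3OC[C@@H](O)[C@H]3OC4)C2=O)cc1C`, which in a functional assay on ECa-109 cells for inhibition, with ECa-109 cell line (Homo sapiens) as the target, read by sulforhodamine B assay (on this read-out higher numbers stand for weaker inhibition and lower numbers for stronger inhibition), gives 4090 nM
compound 2, `CCc1ccc(NC2=CC(=O)c3nc4n(c3C2=O)[C@H]2OC[C@@H](O)[C@H]2OC4)cc1`, which in this assay gives 3080 nM

Of these two numbers, compound 2 has the lower one; compound 1 stands a small distance higher, and that gap lies within the scatter of repeated measurements, so the two compounds cannot be told apart on this read-out. Both share the same core and differ only in the substituents on the aniline ring.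

Compound 3, `Cc1ccc(NC2=CC(=O)c3nc4n(c3C2=O)[C@H]2OC[C@@H](O)[C@H]2OC4)cc1`, has not yet been measured in this assay. It differs from compound 2 by hydrogen in place of methyl on a saturated chain carbon bound to an aromatic carbon. Among the measured compounds shown here, no step between measured compounds of this kind exists here, so the expectation must rest on how little the two measured numbers differ. The change is small and the two measured compounds, which also differ in the substituents on that ring, sit within the scatter of each other, so the expected step from compound 2 to compound 3 is a 1.2-fold higher number from compound 2 to compound 3 (0.09 log units; within the scatter), that is, none beyond the scatter. Compound 3 is therefore estimated at 3800 nM, with a likely range from 1900 nM to 7600 nM.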

Compound 3, half-maximal inhibitory concentration: 3480 nM
Beside the measured number, compound 3's estimate is 1.1-fold (0.04 log units) above it; measured number inside the range.
By their numbers in this assay, from the lowest: compounds 2, 3 and 1 (each within the scatter of the next).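

Replacing methyl with hydrogen on a saturated chain carbon bound to an aromatic carbon, which turns 4-ethylphenyl into 4-methylphenyl, gives a 1.1-fold higher number from compound 2 to compound 3 (0.05 log units; within the scatter) in this assay. Among the compounds shown here, this is the first reading in which that one place alone changes, whereas compound 1 and compound 2 differ by more than this single change and could not isolate it. On this read-out, ethyl and methyl at this place cannot be told apart, and nothing measured here offers an explanation for that.

As far as these compounds go, what remains open is whether a longer chain such as propyl or butyl, or a different kind of group such as an amine or a carboxylic acid, carried on the phenyl ring in place of the ethyl would move the number beyond the scatter. From the compounds shown here alone, it is equally open whether a phenyl ring with no substituent at all, or the same exchange of ethyl for methyl on a ring that carries a second group, would behave as compound 2 and compound 3 do.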